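Aryl variation at the ring carbon: compound 3 to compound 4

The source may report more compounds than this note shows. Statements on the series, on what has been measured and on what is new or still open speak of the compounds shown alone.

Compound 1 `CCN(c1ccc(C#N)c(Cl)c1)c1cc(-c2cccs2)ccc1C` gives 22000 nM in a functional assay on CWR22R cells (Homo sapiens) for antiproliferative activity, read by CCK-8 assay, with a stated time of 6 days; on this read-out lower numbers stand for stronger inhibition and higher numbers for weaker inhibition.
Compound 2 `CCN(c1ccc(C#N)c(Cl)c1)c1cc(-c2cncnc2)ccc1C` gives > 30000 nM in this assay, which is a limit of the assay.
Compound 3 `CCN(c1ccc(C#N)c(Cl)c1)c1cc(-n2ccnc2)ccc1C` gives > 30000 nM in this assay, which is a limit of the assay.
Compound 4 `CCN(c1ccc(C#N)c(Cl)c1)c1cc(-c2ccco2)ccc1C` is not yet measured in this assay.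

Compound 3 stands only at a limit; it sits at the limit of > 30000 nM in this assay, at which 2 of the 3 values shown sit, alongside one other value of the three. The change to compound 4 is furan-2-yl in place of 1H-imidazol-1-yl on an aromatic carbon.

Among the measured compounds shown here, two measured steps bear on this position. From the thiophen-2-yl analogue, an at least 1.3-fold higher number from compound 1 to compound 3 (0.13 log units; that floor lies within the scatter) and an at least 1.3-fold higher number from compound 1 to compound 2 (0.13 log units; that floor lies within the scatter); the step that the two limits leave unreadable from compound 2 to compound 3 cannot be read. The nearest measured comparator for furan-2-yl is compound 1 with thiophen-2-yl, whose value 22000 nM is a number rather than a limit.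

Compound 4 is therefore expected to fall close to compound 1, which would mean an at least 1.2-fold lower number from compound 3 to compound 4 (0.07 log units; that floor lies within the scatter), a move from the limit back to a readable but still weak number. The estimate for compound 4 in this assay is 25000 nM, with a range from 12000 nM to 50000 nM; a further limit remains a real possibility.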

Compound 4, half-maximal inhibitory concentration: > 30000 nM
Compound 4: no number, only a limit; the forecaster's own chance of this, stated with the estimate: 40%; middle value at least 1.2-fold (0.07 log units) from the limit.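

In this assay, compound 4 is one more limit at this ring carbon, > 30000 nM. Compound 1 remains the only one of the four with a number, and the exchange of thiophen-2-yl for furan-2-yl amounts to an at least 1.3-fold higher number from compound 1 to compound 4 (0.13 log units; that floor lies within the scatter), so this closest pair of five-membered aromatic rings is not separated beyond the scatter. The steps to compound 4 from compound 2 and from compound 3 cannot be read, and most of the set now sits at one limit: the limit of > 30000 nM in this assay, at which 3 of the 4 values shown sit.

On these data alone, it remains open whether any group at this ring carbon gives a number clearly stronger than that of compound 1, 22000 nM. A phenyl ring, an aminomethyl group or a carboxylic acid in this place would test that, and only a readable number could rank such groups against thiophen-2-yl.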